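Removing the methoxy group from compound 1: anilide sulfonamide series

This account rests on a few compounds, and the source may have more. Where it says the series, first, only, none or still open, it means among the compounds named here.

Compound 1 `COc1ccc(NS(=O)(=O)c2ccc(NC(=O)c3ccc(Cl)cc3Cl)cc2)cc1` carries a 4-methoxyphenyl group on the sulfonamide nitrogen. In a functional assay on HEK293 cells for agonist activity at probable G-protein coupled receptor 27 (Homo sapiens), read by a luciferase reporter and beta-arrestin recruitment, with a stated time of 10 min (a higher number here means a larger maximal response, a lower number a smaller maximal response), compound 1 gives "not determined" (no result reported), so no number stands for it. Compound 4 `O=C(Nc1ccc(S(=O)(=O)Nc2ccccc2)cc1)c1ccc(Cl)cc1Cl` differs by hydrogen in place of methoxy on an aromatic carbon. Among the measured compounds shown here, the only measured step, a number 21 percentage points lower from compound 2 to compound 3 (beyond the scatter), concerns a halogen exchange on the benzamide ring of compound 2 `O=C(Nc1ccc(S(=O)(=O)Nc2ccccc2)cc1)c1ccc(Cl)cc1F` and compound 3 `O=C(Nc1ccc(S(=O)(=O)Nc2ccccc2)cc1)c1ccc(I)cc1F`, with compound 2 giving 57% and compound 3 giving 36% in this assay; it does not touch the sulfonamide aryl group and therefore bears only indirectly on the change. For the measured compounds named here, no measured step shows the loss of a methoxy group, so no direction can be claimed. Compound 4 is expected to give about 50%, estimated between 25% and 75%, resting on the value of compound 2 57% as the nearest measured dichloro-type anilide.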

Compound 4, largest response reached (Emax), in percent of the reference or control that the assay uses: 100%
Estimate against measurement, compound 4: 50 percentage points below; the measured number lies above the stated range.
By their numbers in this assay, from the lowest: compound 3; then compound 2; then compound 4.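

In this assay compound 4 stands highest of the three compounds with numbers: chloro in place of fluoro on an aromatic carbon gives a number 43 percentage points higher from compound 2 to compound 4 (beyond the scatter) and 2,4-dichlorophenyl in place of 2-fluoro-4-iodophenyl gives a number 64 percentage points higher from compound 3 to compound 4 (beyond the scatter) with the anilino group unchanged. The group on the carbonyl carbon therefore moves the maximal response widely in this series, while the step from compound 1 to compound 4 cannot be read. No measurement here explains these differences.

From the compounds shown here alone, the effect of the methoxy group on compound 4 remains open. So does the response to an amine or a carboxylic acid on that aromatic carbon.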